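Swapping dimethyl for dimethoxy on compound 2

The source may hold more compounds than are shown below. What is called first, only, known or untested is meant among the compounds shown, and "the series" means these compounds.

In a functional assay on CHP-134 cells (Homo sapiens) for antiproliferative activity, with a stated time of 72 h (on this read-out higher numbers stand for weaker inhibition and lower numbers for stronger inhibition), compound 1 `Cc1ccc(NC(=O)CCN(Cc2ccc(C(=O)NO)cc2)C(=O)c2cc(C)cc(C)c2)cc1` gives 380 nM and compound 3 `Cc1ccc(CNC(=O)CCN(Cc2ccc(C(=O)NO)cc2)C(=O)c2ccc(N(C)C)cc2)cc1` gives 420 nM. Compound 2 `Cc1cc(C)cc(C(=O)N(CCC(=O)NCc2ccccc2)Cc2ccc(C(=O)NO)cc2)c1` gives 2030 nM, the highest number of the three and so the weakest inhibition, beyond the scatter from both others. The next structure is compound 4 `COc1cc(OC)cc(C(=O)N(CCC(=O)NCc2ccccc2)Cc2ccc(C(=O)NO)cc2)c1`, which differs from compound 2 as follows: 3,5-dimethoxyphenyl in place of 3,5-dimethylphenyl on a carbonyl carbon. Within the data shown here, the only measured single-place step, a 5.3-fold higher number from compound 1 to compound 2 (0.73 log units; beyond the scatter), is modest and involves benzyl in place of 4-methylphenyl on an amide-type nitrogen. That is a different place from the carbonyl carbon changed here, so it gives no direct guide to the size of this step. Compound 3 carries another group on its carbonyl carbon but also differs from compound 2 elsewhere, so it isolates nothing either. Among the measured compounds shown here, with no measured step at this place, no change beyond the scatter is expected in this assay. The expected step is a 1.2-fold lower number from compound 2 to compound 4 (0.08 log units; within the scatter). For compound 4 the estimated value is 1700 nM, with an expected range of 700 nM to 4000 nM.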

Compound 4, half-maximal inhibitory concentration: 12300 nM
Beside the measured number, compound 4's estimate is 7.2-fold (0.86 log units) below it; the whole stated range lies below it.
By their numbers in this assay, from the lowest: compounds 1 and 3 (each within the scatter of the next); then compound 2; then compound 4.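

In this assay, the group on the carbonyl carbon proves to be a place that responds: 3,5-dimethoxyphenyl in place of 3,5-dimethylphenyl gives a 6.1-fold higher number from compound 2 to compound 4 (0.78 log units; beyond the scatter), which means weaker inhibition. Among these compounds, the only earlier single-place step, a 5.3-fold higher number from compound 1 to compound 2 (0.73 log units; beyond the scatter), concerned the amide-type nitrogen, so this is the first measured sign that the carbonyl side also counts, and here the entering group brings in two oxygen atoms and two hydrogen-bond acceptors while keeping the same aromatic ring. Nothing measured here explains why this change weakens inhibition.

The compounds shown leave open how an unsubstituted phenyl, a 3,5-dihydroxyphenyl or a phenyl bearing an amine would behave on this carbonyl carbon. They also leave open whether the same swap would have a comparable effect with the 4-methylphenyl group of compound 1 on the amide-type nitrogen.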